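The compounds below may be only part of what the source reports. "The series", "measured", "known", "first", "only" and "open" are said of these compounds alone.

Compound 1 `CC(C)CN(CC(C)C)c1ccc(/C(=N/O)Nc2ccc(F)c(Br)c2)cc1NC(=O)NC1CCCCC1` gives 1340 nM in an assay on HeLa cells for inhibition of Indoleamine 2,3-dioxygenase 1 (Homo sapiens); on this read-out higher numbers stand for weaker inhibition and lower numbers for stronger inhibition. Compound 2 `Cc1ccc(NC(=O)Nc2cc(/C(=N/O)Nc3ccc(C)cc3)ccc2N(CC(C)C)CC(C)C)cc1` gives 1340 nM. Compound 3 `CC(C)CN(CC(C)C)c1ccc(/C(=N/O)Nc2ccc(F)c(Br)c2)cc1NC(=O)Nc1cncnc1` gives 860 nM.

Compound 3 shows the lowest of the three numbers, but its gaps to compound 1 and to compound 2 both lie within the scatter, so no ranking can be drawn from them. Compound 4 `Cc1ccc(N/C(=N\O)c2ccc(N(CC(C)C)CC(C)C)c(NC(=O)Nc3cncnc3)c2)cc1` carries 4-methylphenyl in place of 3-bromo-4-fluorophenyl on an amine nitrogen. Within the data shown here, no measured pair differs in this place alone. Compounds 1 and 2 differ at this place and at one further one, and their two numbers are the same. Among the measured compounds shown here, the only single step seen, a 1.6-fold lower number from compound 1 to compound 3 (0.19 log units; within the scatter), concerns a different place. No step beyond the scatter is therefore expected, and compound 4 is estimated at 900 nM, a change of a 1.0-fold higher number from compound 3 to compound 4 (0.02 log units; within the scatter), within 400 nM to 2000 nM.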

Compound 4, half-maximal inhibitory concentration: 440 nM
The estimate for compound 4 lay 2.0-fold (0.31 log units) above the measured number, within the range that was stated.
By their numbers in this assay, from the lowest: compounds 4, 3, 1 and 2 (each within the scatter of the next, the first and the last beyond it).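

At the amine nitrogen, 4-methylphenyl in place of 3-bromo-4-fluorophenyl gives a step that cannot be told from scatter, a 2.0-fold lower number from compound 3 to compound 4 (0.29 log units; within the scatter). Among these compounds, with 4-methylphenyl held on that nitrogen, the amide-type nitrogen gives the first step beyond the scatter, though a modest one: pyrimidin-5-yl in place of 4-methylphenyl gives a 3.0-fold lower number from compound 2 to compound 4 (0.48 log units; beyond the scatter). No evidence is at hand to explain either step.

Going by these compounds, what a pyridinyl ring or a carboxylic acid would give on the amide-type nitrogen remains open. So does the outcome of a nitrile on the aromatic ring at the amine nitrogen.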